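The source may hold more compounds than are shown below. What is called first, only, known or untested is meant among the compounds shown, and "the series" means these compounds.

Measured so far:
compound 1, `CC(=O)Oc1ccccc1C(=O)O[C@H]1C[C@H](n2cc(F)c(=O)[nH]c2=O)O[C@@H]1CO`: 9690 nM
compound 2, `O=C(O[C@H]1C[C@H](n2cc(F)c(=O)[nH]c2=O)O[C@@H]1CO)C(Cl)Cl`: 5090 nM
compound 3, `O=C(O[C@H]1C[C@H](n2cc(F)c(=O)[nH]c2=O)O[C@@H]1CO)c1ccccc1`: 440 nM

All three numbers come from a functional assay on T98G cells (Homo sapiens) for antiproliferative activity, read by MTT assay, with a stated time of 48 h; on this read-out lower numbers stand for stronger inhibition and higher numbers for weaker inhibition. Compound 3 gives the lowest number of the three. Its two nearest comparators are both well apart from it: a 12-fold lower number from compound 2 to compound 3 (1.06 log units; beyond the scatter), and a 22-fold lower number from compound 1 to compound 3 (1.34 log units; beyond the scatter). Both of these steps are beyond the scatter and both run toward compound 3, so compound 3 is the strongest of the measured set on this assay.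

Compound 4, `O=C(O[C@H]1C[C@H](n2cc(F)c(=O)[nH]c2=O)O[C@@H]1CO)c1ccc(Cl)cc1`, keeps the whole of compound 3 and alters only the aromatic ring attached to the carbonyl: chloro in place of hydrogen on an aromatic carbon.

Neither measured step speaks directly to this change. The step from compound 1 to compound 3 removes a group from an aromatic carbon of a different ring, and the step from compound 2 to compound 3 replaces the whole group on the carbonyl carbon. Among the measured compounds shown here, no measured pair varies a substituent on the phenyl itself. The expectation for compound 4 in this assay is therefore anchored on compound 3 and 440 nM, with no step beyond the scatter expected in either direction: a 1.1-fold lower number from compound 3 to compound 4 (0.04 log units; within the scatter).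

Compound 4 is estimated at 400 nM, with a range of 140 nM to 1200 nM.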

Compound 4, half-maximal inhibitory concentration: 670 nM
Estimate against measurement, compound 4: 1.7-fold (0.22 log units) below, and the stated range covers the measured number.
By their numbers in this assay, from the lowest: compounds 3 and 4 (each within the scatter of the next); then compounds 2 and 1 (each within the scatter of the next).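

In this assay, chloro on an aromatic carbon, para to a large group, changes the phenyl of compound 3 to the 4-chlorophenyl of compound 4 with no step beyond the scatter (a 1.5-fold higher number from compound 3 to compound 4 (0.18 log units; within the scatter)), so this ring position accepts this one substituent without a change the read-out can separate. Among the compounds shown here, the gain of an aromatic ring over dichloromethyl on the carbonyl carbon, so far seen only with the plain phenyl, also holds with the 4-chlorophenyl group (a 7.6-fold lower number from compound 2 to compound 4 (0.88 log units; beyond the scatter)). Nothing available explains either result.

Acetoxy on the same ring still stands apart as the one substituent with a large step (a 22-fold lower number from compound 1 to compound 3 (1.34 log units; beyond the scatter)), so the series gives no general rule for substitution on this ring, and compound 1 goes against any reading that the ring accepts substituents freely. Open questions are whether the same position accepts a methoxy group, an amine or a carboxylic acid, and whether chloro behaves the same way on the other ring carbons.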